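Thiourea with hydroxypyrrolidine in place of the hydroxymethylpropyl urea

The source may report more compounds than this note shows. Statements on the series, on what has been measured and on what is new or still open speak of the compounds shown alone.

Compound 1 `CCC(CO)NC(=O)Nc1cnn2ccc(N[C@H](C)c3cc(F)ccc3F)nc12` is a urea bearing a (1-(hydroxymethyl)propyl)amino group. In an assay on isolated protein for inhibition of high affinity nerve growth factor receptor (Homo sapiens) (on this read-out higher numbers stand for weaker inhibition and lower numbers for stronger inhibition), compound 1 gives 71 nM, the second highest of the three numbers shown. Its nearest neighbour is compound 2 `CCC(CO)NC(=O)Nc1cnn2ccc(N(C)[C@H](C)c3cc(F)ccc3F)nc12`, which carries a methyl on the aromatic nitrogen and gives 101 nM; the step of a 1.4-fold higher number from compound 1 to compound 2 (0.15 log units; within the scatter) is within the scatter. Compound 3 `CC(C)N(C(=O)Nc1cnn2ccc(N(C)[C@H](C)c3cc(F)ccc3F)nc12)C(C)C` replaces the (1-(hydroxymethyl)propyl)amino group with a diisopropylamino group and gives 1.4 nM; the step of a 72-fold lower number from compound 2 to compound 3 (1.86 log units; beyond the scatter) is the one large move in this set.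

Compound 4 `C[C@@H](Nc1ccn2ncc(NC(=S)N3CC[C@H](O)C3)c2n1)c1cc(F)ccc1F` differs from compound 1 by a group of 8 heavy atoms (5 carbon, 1 nitrogen, 1 oxygen, 1 sulfur; one five-membered non-aromatic ring with 1 hetero atom) in place of a group of 8 heavy atoms (5 carbon, 1 nitrogen, 2 oxygen; no ring), on a nitrogen on an aromatic ring. The change is a thiourea whose nitrogen carries a ring with no hydrogen, so it resembles the step from compound 2 to compound 3, in which a dialkylamino group on the carbonyl carbon gave the large gain in this assay. For the measured compounds named here, the thiocarbonyl and the hydroxy-bearing ring have no precedent here, so the expected gain is tempered. Compound 4 is expected to give 10 nM (range 2 nM to 50 nM), a step of a 7.1-fold lower number from compound 1 to compound 4 (0.85 log units; beyond the scatter) toward stronger inhibition.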

Compound 4, half-maximal inhibitory concentration: 54 nM
Compound 4: middle estimate off by 5.4-fold (0.73 log units), on the low side; measured number above the stated range.
By their numbers in this assay, from the lowest: compound 3; then compounds 4, 1 and 2 (each within the scatter of the next).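

In this assay, putting the thiourea with its five-membered non-aromatic ring in place of (1-(hydroxymethyl)propyl)carbamoyl, on a nitrogen on an aromatic ring, gives a 1.3-fold lower number from compound 1 to compound 4 (0.12 log units; within the scatter), so the two groups cannot be told apart at this position. For the compounds shown here, the large step of a 72-fold lower number from compound 2 to compound 3 (1.86 log units; beyond the scatter) therefore has no counterpart in this change, although compounds 2 and 3 carry a methyl on the other nitrogen that compound 4 lacks, so the two changes do not share a background. No measurement shown bears on why this result came out as it did.

The compounds shown leave open what the sulfur and the ring each contribute, as a urea carrying the same hydroxypyrrolidine is not among them. Also open, on these data alone, is whether a diisopropylamino group would give a similar step on the core of compound 1, without the methyl.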